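Shortening the hydroxamic acid chain of compound 1

This account rests on a few compounds, and the source may have more. Where it says the series, first, only, none or still open, it means among the compounds named here.

Measured so far in a functional assay on PC-3 cells (Homo sapiens) for antiproliferative activity, read by sulforhodamine B assay, with a stated time of 48 h; on this read-out lower numbers stand for stronger inhibition of growth and higher numbers for weaker inhibition of growth:
compound 1 `CC(C)CCc1c(OCCCCCCCC(=O)NO)ccc(CCC(=O)NO)c1O` gives 1730 nM
compound 2 `CC(C)CCc1c(OCCCCCCC(=O)NO)ccc2ccc(=O)oc12` gives 520 nM

Compound 1 holds the higher of these two numbers, which marks it as the weaker growth inhibitor of the pair, and the gap to compound 2 lies beyond the scatter.

Compound 3 `CC(C)CCc1c(OCCCCCC(=O)NO)ccc(CCC(=O)NO)c1O` has not yet been measured. It keeps the core of compound 1 and changes one place, with hydroxycarbamoyl in place of 2-(hydroxycarbamoyl)ethyl on a saturated chain carbon, five bonds along the chain from an oxygen on an aromatic ring and the chain ends up shorter.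

Within the data shown here, no measured pair shows this change alone, so any forecast is uncertain. The expected step of a 1.4-fold higher number from compound 1 to compound 3 (0.16 log units; within the scatter) in this assay is small and upward, with no shift beyond the scatter. Compound 3 is estimated to give 2500 nM with 900 nM to 7000 nM as the expected range.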

Compound 3, concentration for 50% growth inhibition: 2520 nM
Compound 3: the middle estimate sits 1.0-fold (0.00 log units) below what was measured; the measured number falls inside the stated range.
By their numbers in this assay, from the lowest: compound 2; then compounds 1 and 3 (each within the scatter of the next).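

In this assay, among these compounds, the swap of 2-(hydroxycarbamoyl)ethyl for hydroxycarbamoyl on this saturated chain carbon gives a 1.5-fold higher number from compound 1 to compound 3 (0.16 log units; within the scatter) and forms the first pair here that differs in one place. The earlier compounds shown here could not isolate chain length, but this pair shows that this one shortening leaves the two compounds indistinguishable in growth inhibition. No measurement at hand speaks to what lies behind this result.

As far as these compounds go, a single step within the scatter cannot establish a trend with chain length, so it remains open whether a longer chain at this place would leave the read-out just as unmoved. From the compounds shown here alone, it is equally open whether a carboxylic acid or an amine in place of the hydroxycarbamoyl group at the chain end would keep growth inhibition at this level.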